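Toward compound 4: a nitro-bearing analogue in the cytotoxicity test

The source may report more compounds than this note shows. Statements on the series, on what has been measured and on what is new or still open speak of the compounds shown alone.

Measured so far:
compound 1 `O=C1c2ccccc2C(=O)N1CCOC(=S)N(C(=O)c1ccc(Br)cc1)c1ccc(Br)cc1`: 73000 nM
compound 2 `Cc1ccc(N(C(=O)c2cccc(C)c2)C(=S)OCCN2C(=O)c3ccccc3C2=O)cc1`: > 100000 nM
compound 3 `O=C1c2ccccc2C(=O)N1CCOC(=S)N(C(=O)c1cccc(F)c1F)c1ccc(Cl)cc1`: 58000 nM

In an ADME assay on MT4 cells (Homo sapiens) for cytotoxicity, read by MTT assay (a higher number here means that more compound is tolerated, a lower number that less compound is tolerated), compound 3 gives 58000 nM. Compound 1, at 73000 nM, sits within the scatter of compound 3, so the two are not told apart. Compound 2 reached only a limit of this assay, (the limit of > 100000 nM in this assay, at which 1 of the 3 values shown sits), and gives no number. Compound 4 `O=C1c2ccccc2C(=O)N1CCOC(=S)N(C(=O)c1ccc([N+](=O)[O-])cc1Cl)c1ccc(Cl)cc1` has not yet been measured. It differs from compound 3 in one place: 2-chloro-4-nitrophenyl in place of 2,3-difluorophenyl on a carbonyl carbon. Within the data shown here, no measured pair shows the effect of such a change, so the expected step from compound 3 to compound 4 is a 1.1-fold lower number from compound 3 to compound 4 (0.02 log units; within the scatter), not beyond the scatter. Compound 4 is therefore estimated at 55000 nM, between 25000 nM and 100000 nM.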

Compound 4, half-maximal cytotoxic concentration: 19000 nM
The estimate for compound 4 lay 2.9-fold (0.46 log units) above the measured number; measured number outside the range, below it.
By their numbers in this assay, from the lowest: compound 4; then compounds 3 and 1 (each within the scatter of the next). At a limit, above all of these: compound 2.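

In this assay the change from 2,3-difluorophenyl to 2-chloro-4-nitrophenyl on a carbonyl carbon gives a 3.1-fold lower number from compound 3 to compound 4 (0.48 log units; beyond the scatter) and is the first step shown that lies beyond the scatter. The earlier compounds shown here formed no pair differing in one place, so only now is it clear that this position can shift how much compound the cells tolerate. Nothing measured here bears on why the number moved.

As far as these compounds go, the entering group differs from the leaving one in more than one way, so the separate parts played by the nitro group and the chlorine stay unknown. Also open, from the compounds shown here alone, is how an amine or a carboxylic acid at this place would read.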